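The compounds below may be only part of what the source reports. "The series", "measured", "known", "first", "only" and "open" are said of these compounds alone.

Compound 2 `COc1ccc(-c2cc(=O)c3c(OC)cc(OC)cc3n2S(=O)(=O)c2ccc(Br)cc2)cc1` stands only at a limit in an ADME assay on BJ cells (Homo sapiens) for antiproliferative activity, with a stated time of 72 h; a lower number here means that less compound is needed, a higher number that more compound is needed for the effect: in this assay compound 2 gives > 86200 nM, which is a limit of the assay and not a number. Within the data shown here, the one compound it can be set beside is compound 1 `COc1ccc(-c2cc(=O)c3c(OC)cc(OC)cc3[nH]2)cc1`. In this assay compound 1 gives > 62000 nM, likewise a limit. The step that the two limits leave unreadable from compound 1 to compound 2 is therefore unreadable, since both ends rest on limits, the limit of > 62000 nM in this assay, at which 1 of the 2 values shown sits, and (the limit of > 86200 nM in this assay, at which 1 of the 2 values shown sits). Compound 3 `COc1ccc(-c2cc(=O)c3c(OC)cc(OC)cc3n2S(=O)(=O)Cc2ccccc2)cc1` differs from compound 2 by benzyl in place of 4-bromophenyl on a sulfonyl sulfur. Among the measured compounds shown here, the only measured step that bears on this change is the unreadable one from compound 1 to compound 2, so no direction can be drawn from what has been measured, and the two limits suggest that compound 3 will also sit at a limit. The expected step that the limit leaves unreadable from compound 2 to compound 3 is next to nothing. Compound 3 is estimated at 100000 nM, within 30000 nM to 300000 nM, most likely reported only as a limit.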

Compound 3, half-maximal effective concentration: > 34400 nM
Compound 3: only a limit was reported (the forecaster's own chance of this, stated with the estimate: 85%); the middle value does not contradict the limit.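

In this assay compound 3 gives > 34400 nM, a limit and not a number. Among these compounds, compound 1 and compound 2 also rest on limits, so no step among the three can be read. What the compounds shown leave open is the actual half-maximal effective concentration of each.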